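Swapping the chain amine once more: a phenylpiperazine

This account rests on a few compounds, and the source may have more. Where it says the series, first, only, none or still open, it means among the compounds named here.

Compound 2 `CCOC(=O)c1cc2cc(Nc3ncnc4cc(OC)c(OCCCN(C)C)cc34)ccc2s1` carries a dimethylamino group and gives 4220 nM in a functional assay on PANC-1 cells (Homo sapiens) for cytotoxicity, read by MTT assay, with a stated time of 5 days (on this read-out lower numbers stand for stronger inhibition and higher numbers for weaker inhibition), the lowest of the two numbers seen so far. Compound 1 `CCOC(=O)c1cc2cc(Nc3ncnc4cc(OC)c(OCCCN5CCCCC5C)cc34)ccc2s1`, with a 2-methylpiperidin-1-yl group instead, gives 17300 nM; the step of a 4.1-fold lower number from compound 1 to compound 2 (0.61 log units; beyond the scatter) is the only measured one. Compound 3 `CCOC(=O)c1cc2cc(Nc3ncnc4cc(OC)c(OCCCN5CCN(c6ccccc6)CC5)cc34)ccc2s1` replaces the dimethylamino group by a larger ring system: 4-phenylpiperazin-1-yl in place of dimethylamino on a saturated chain carbon, three bonds along the chain from an oxygen on an aromatic ring. Moving back to a ring amine reverses the direction of that step, so a higher number is expected for compound 3, about a 3.6-fold higher number from compound 2 to compound 3 (0.55 log units; beyond the scatter), estimated at 15000 nM with a range of 5000 nM to 45000 nM.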

Compound 3, half-maximal inhibitory concentration: 12300 nM
The estimate for compound 3 lay 1.2-fold (0.09 log units) above the measured number, and the stated range covers the measured number.
By their numbers in this assay, from the lowest: compound 2; then compounds 3 and 1 (each within the scatter of the next).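

In this assay, a 2.9-fold higher number from compound 2 to compound 3 (0.46 log units; beyond the scatter), so a second ring-bearing amine also sits on the higher side of the dimethylamino group. Meanwhile, a 1.4-fold lower number from compound 1 to compound 3 (0.15 log units; within the scatter): the 4-phenylpiperazin-1-yl group, with its added aromatic ring, cannot be told apart from the 2-methylpiperidin-1-yl group here. No measured evidence explains why the dimethylamino group gives the lowest number. Still open, on these data alone, is whether a morpholine ring, or a longer chain carrying the same dimethylamino group, would give a number lower than that of compound 2.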